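The source may hold more compounds than are shown below. What is called first, only, known or untested is meant among the compounds shown, and "the series" means these compounds.

The series shares the core of compound 3 `COc1cc(-c2nnc(SCC(=O)c3ccc(Cl)cc3)n2N2C(=O)c3ccccc3C2=O)cc(OC)c1OC` and varies the group on a saturated chain carbon bound to a sulfur. Among the compounds with values here, in a functional assay on MKN-45 cells (Homo sapiens) for cytotoxicity, read by MTT assay, with a stated time of 48 h (a higher number here means a weaker inhibitor, a lower number a stronger inhibitor), compound 3 gives 26600 nM, the only plain number among the three values shown. Compound 1 `COc1cc(-c2nnc(SCc3ccccc3Cl)n2N2C(=O)c3ccccc3C2=O)cc(OC)c1OC` carries 2-chlorophenyl at that position; in this assay compound 1 reaches only a limit of the assay, > 200000 nM. Compound 2 `C#CCSc1nnc(-c2cc(OC)c(OC)c(OC)c2)n1N1C(=O)c2ccccc2C1=O` carries ethynyl there; in this assay compound 2 likewise returns a limit, > 200000 nM. The shared ceiling is the limit of > 200000 nM in this assay, at which 2 of the 3 values shown sit. The two readable steps both end at compound 3: an at least 7.5-fold lower number from compound 1 to compound 3 (0.87 log units; beyond the scatter) and an at least 7.5-fold lower number from compound 2 to compound 3 (0.87 log units; beyond the scatter). The step between compound 1 and compound 2 cannot be sized, as both sit at the limit. Compound 4 `COc1cc(-c2nnc(SC)n2N2C(=O)c3ccccc3C2=O)cc(OC)c1OC` strips the position bare: hydrogen in place of (4-chlorophenyl)carbonyl on a saturated chain carbon bound to a sulfur. In both measured steps the entry of (4-chlorophenyl)carbonyl lowered the number beyond the scatter, so its removal from compound 3 is expected to raise the number, plausibly back toward the ceiling at which compound 1 and compound 2 sit. For compound 4 the estimate in this assay is therefore 150000 nM, within 40000 nM to 200000 nM, the expected step being a 5.6-fold higher number from compound 3 to compound 4 (0.75 log units; beyond the scatter).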

Compound 4, half-maximal inhibitory concentration: > 200000 nM
Compound 4 was reported as a limit; the forecaster's own chance of this, stated with the estimate: 60%; middle value at least 1.3-fold (0.12 log units) from the limit.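

In this assay, the loss of (4-chlorophenyl)carbonyl gives an at least 7.5-fold higher number from compound 3 to compound 4 (0.87 log units; beyond the scatter), and this is a bound rather than a full size, as the value of compound 4 is a limit of the assay. The shared core with only methylsulfanyl at this place therefore gives no plain number, so the number of compound 3 does not come from the core alone, and the bare position provides no measured baseline for the series. Compound 3 remains the only one of the four with a plain number, and the steps among compound 1, compound 2 and compound 4 cannot be read, leaving no order among hydrogen, ethynyl and 2-chlorophenyl at this place: the limit of > 200000 nM in this assay, at which 3 of the 4 values shown sit.

The compounds shown do not separate the part played by the carbonyl from that of the chlorine in (4-chlorophenyl)carbonyl, a question that an unsubstituted phenylcarbonyl or a 4-chlorophenyl lacking the carbonyl would address. From the compounds shown here alone, it also remains open whether a carboxylic acid or an amine at the same chain carbon would move the number off the ceiling.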